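Methoxy for methyl on a sulfonate ester, second time around

This account rests on a few compounds, and the source may have more. Where it says the series, first, only, none or still open, it means among the compounds named here.

Compound 1 `Cc1ccc(S(=O)(=O)Oc2ccccc2/C=C(\C#N)C(=O)Nc2nnc(Cc3ccccc3)s2)cc1`: 16%
Compound 2 `COc1ccc(S(=O)(=O)Oc2ccccc2/C=C(\C#N)C(=O)Nc2nnc(Cc3ccccc3)s2)cc1`: 100%
Compound 3 `Cc1ccc(S(=O)(=O)Oc2ccccc2/C=C(\C#N)C(=O)Nc2nnc(Cc3ccc(F)cc3)s2)cc1`: "not active" (no number reported), no number given

Three compounds share one core and were tested in a functional assay on HL-60 cells (Homo sapiens) for inhibition, read by CCK-8 assay, with a stated time of 48 h, tested at 20 uM; on this read-out lower numbers stand for less inhibition of growth and higher numbers for more inhibition of growth at the one concentration tested. Compound 1 `Cc1ccc(S(=O)(=O)Oc2ccccc2/C=C(\C#N)C(=O)Nc2nnc(Cc3ccccc3)s2)cc1` gives 16% in this assay, while compound 2 `COc1ccc(S(=O)(=O)Oc2ccccc2/C=C(\C#N)C(=O)Nc2nnc(Cc3ccccc3)s2)cc1` gives 100%. The two differ in a single place, (methoxy in place of methyl on an aromatic carbon), and the step is a number 84 percentage points higher from compound 1 to compound 2 (beyond the scatter). Compound 3 `Cc1ccc(S(=O)(=O)Oc2ccccc2/C=C(\C#N)C(=O)Nc2nnc(Cc3ccc(F)cc3)s2)cc1` carries a different core; its difference from compound 1 is fluoro in place of hydrogen on an aromatic carbon. In this assay compound 3 was reported as "not active" (no number reported), with no number attached to that result.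

Compound 4 `COc1ccc(S(=O)(=O)Oc2ccccc2/C=C(\C#N)C(=O)Nc2nnc(Cc3ccc(F)cc3)s2)cc1` has not yet been measured in this assay. It stands to compound 3 as compound 2 stands to compound 1: the change is methoxy in place of methyl on an aromatic carbon, the same change made at the same place. Within the data shown here, whether the step repeats on the core of compound 3 cannot be read from the data, since only one instance of the change has been measured. Resting on compound 1 and compound 2, where the same change gave a number 84 percentage points higher from compound 1 to compound 2 (beyond the scatter), the account expects a large rise from the inactive result of compound 3. Given that single precedent, compound 4 is estimated at 60% in this assay, with an expected range from 10% to 100%.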

Compound 4, percent growth inhibition at one concentration: 100%
Beside the measured number, compound 4's estimate is 40 percentage points below it; the measured number falls inside the stated range.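

In this assay compound 3 is reported as "not active" (no number reported) and compound 4 gives 100%, so 4-methylphenyl to 4-methoxyphenyl turns an inactive result into a numbered one on the core of compound 3, as the same change raised the result on the core of compound 1, with a number 84 percentage points higher from compound 1 to compound 2 (beyond the scatter). The size of the step on the second core cannot be read, as compound 3 carries no number, so the two instances agree in direction only, and two cores make no rule for the whole series; fluoro in place of hydrogen gives no change at the digits printed from compound 2 to compound 4 (within the scatter), but with both compounds at the top of this read-out at the one concentration tested, this does not show that the fluoro leaves potency untouched. Nothing given here bears on why the change acts as it does.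

Still open, going by these compounds, is whether an amine or a carboxylic acid in place of the methoxy, or a longer chain such as ethoxy, would hold the same result in this assay on either core. Also open, on these data alone, is whether chloro in place of the fluoro would behave as compound 4 does, and how compound 2 and compound 4 compare at lower concentrations.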